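Cyclopropyl to 2-methoxyethyl: a clearance note

The source may report more compounds than this note shows. Statements on the series, on what has been measured and on what is new or still open speak of the compounds shown alone.

Measured so far in an in vitro ADME assay on microsomes from liver (Homo sapiens) for metabolic stability (a lower number here means slower removal, a higher number faster removal of the compound), across the series:
Compound 1 `COCCc1nc2nc(C)cc(Nc3ccc(S(F)(F)(F)(F)F)cc3)n2n1` gives 11.5 mL.min-1.g-1
Compound 2 `Cc1cc(Nc2ccc(C(F)(F)F)cc2)n2nc(C3CC3)nc2n1` gives < 5 mL.min-1.g-1 as a limit, not a number

Compound 2 sits at the limit of < 5 mL.min-1.g-1 in this assay, at which 1 of the 2 values shown sits, and so offers no exact starting point.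

Compound 3 `COCCc1nc2nc(C)cc(Nc3ccc(C(F)(F)F)cc3)n2n1` is the next step from compound 2. The change is 2-methoxyethyl in place of cyclopropyl on an aromatic carbon with 2-methoxyethyl in place of cyclopropyl on an aromatic carbon.

Among the compounds with values here, no measured step isolates this swap. Compound 1 also carries 2-methoxyethyl and gives 11.5 mL.min-1.g-1 in this assay so a modest move upward is expected. The estimated change is an at least 1.6-fold higher number from compound 2 to compound 3 (0.20 log units; that floor lies within the scatter) and a reading that stays at the limit remains possible. Compound 3 is expected at 8 mL.min-1.g-1 with an estimated range of 5 mL.min-1.g-1 to 14 mL.min-1.g-1 around it.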

Compound 3, intrinsic clearance in microsomes: 9 mL.min-1.g-1
Compound 3: middle estimate off by 1.1-fold (0.05 log units), on the low side; the range from low to high includes it.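

In this assay, within the data shown here, 2-methoxyethyl in place of cyclopropyl on the aromatic carbon between two ring nitrogen atoms gives an at least 1.8-fold higher number from compound 2 to compound 3 (0.25 log units; that floor lies within the scatter), the first reading of a change at this position, although it fixes only a floor. Compound 2 supplies a limit and not a number as the starting point: the limit of < 5 mL.min-1.g-1 in this assay, at which 1 of the 3 values shown sits. With 2-methoxyethyl held in place, trifluoromethyl in place of the larger fluorinated group of compound 1 gives a 1.3-fold lower number from compound 1 to compound 3 (0.11 log units; within the scatter), so this aromatic-carbon change does not separate the two readings.

Going by these compounds, the true size of the cyclopropyl to 2-methoxyethyl step remains unknown while compound 2 stands at a limit. Also open, on these data alone, is how a primary amine or a longer alkyl chain on the same aromatic carbon would read in this assay.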